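Swapping Ethoxycarbonyl for Phenyl on the Shared Core

The compounds below may be only part of what the source reports. "The series", "measured", "known", "first", "only" and "open" are said of these compounds alone.

Compound 1 `O=C(CCCCC1CCSS1)NCc1cn(CCCCCOc2ccc3ccc(=O)oc3c2)nn1`: 71.3%
Compound 2 `CC(=O)c1cc2ccc(OCCCCCn3cc(CNC(=O)CCCCC4CCSS4)nn3)cc2oc1=O`: 20.8%
Compound 3 `CCOC(=O)c1cc2ccc(OCCCCCn3cc(CNC(=O)CCCCC4CCSS4)nn3)cc2oc1=O`: 38.3%

Of the compounds shown here, three have been measured in a functional assay on PC-12 cells (Rattus norvegicus) for cytotoxicity, read by MTT assay, with stated times of 3 h and 2 h, tested at 10 uM; a lower number here means a weaker effect, a higher number a stronger effect of the compound at the concentration tested. Compound 3 stands second highest of the three: compound 2 sits beneath it, the step being a number 17.5 percentage points higher from compound 2 to compound 3 (beyond the scatter), and compound 1 stands above it, the step being a number 33 percentage points lower from compound 1 to compound 3 (beyond the scatter).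

The next compound is compound 4 `O=C(CCCCC1CCSS1)NCc1cn(CCCCCOc2ccc3cc(-c4ccccc4)c(=O)oc3c2)nn1`. It differs from compound 3 by phenyl in place of ethoxycarbonyl on an aromatic carbon.

For the measured compounds named here, two measured steps bear on this position. Adding acetyl to the bare carbon gave a number 50.5 percentage points lower from compound 1 to compound 2 (beyond the scatter), and adding ethoxycarbonyl gave a number 33 percentage points lower from compound 1 to compound 3 (beyond the scatter), so any group on this carbon has so far lowered the read-out. Exchanging one such group for another gave only a number 17.5 percentage points higher from compound 2 to compound 3 (beyond the scatter). Going by the values given here, no measured step covers phenyl, so the estimate for compound 4 is uncertain and is expected to fall near the substituted compounds rather than compound 1. The expected step is a number 3.3 percentage points lower from compound 3 to compound 4 (within the scatter), within the scatter. Compound 4 is thus estimated at 35%, with a range from 15% to 60%.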

Compound 4, a percentage reported as activity, at one concentration (the size of the read-out at that concentration, not a potency): 26.3%
The estimate for compound 4 lay 8.7 percentage points above the measured number; the measured number falls inside the stated range.
By their numbers in this assay, from the lowest: compounds 2 and 4 (each within the scatter of the next); then compound 3; then compound 1.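

Phenyl now joins acetyl and ethoxycarbonyl on this aromatic carbon, and in this assay it also leaves the read-out well short of the bare carbon, with a number 45 percentage points lower from compound 1 to compound 4 (beyond the scatter) as the step. Going from acetyl to phenyl gives a number 5.5 percentage points higher from compound 2 to compound 4 (within the scatter) and so leaves the two level, while going from ethoxycarbonyl to phenyl gives a number 12 percentage points lower from compound 3 to compound 4 (beyond the scatter) and so sets those two apart. A lower read-out on this carbon is therefore seen with a group that holds no carbonyl, as well as with two groups that do. Nothing measured here explains why any of these groups lowers the read-out. As far as these compounds go, whether a smaller group such as methyl, or an amine or a carboxylic acid on this carbon, would lower it as well remains open.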